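Changing the aryl group on the triazole nitrogen once more

The compounds below may be only part of what the source reports. "The series", "measured", "known", "first", "only" and "open" are said of these compounds alone.

Within the data shown here, compound 2, `Cc1cc(C)cc(-n2nncc2CN2C(=O)C3(C(C#N)=C(N)Oc4c(N)cc5nc6ccccc6nc5c43)c3ccccc32)c1`, is one of two compounds so far tested in a functional assay on HepG2 cells (Homo sapiens) for antiproliferative activity, read by MTT assay, with a stated time of 48 h; a higher number here means a weaker inhibitor, a lower number a stronger inhibitor. In this assay compound 2 gives only a limit, > 50000 nM. Compound 1, `CC(=O)Nc1ccc(-n2nncc2CN2C(=O)C3(C(C#N)=C(N)Oc4c(N)cc5nc6ccccc6nc5c43)c3ccccc32)cc1`, shares the same core and differs only in the group on the aromatic nitrogen; in this assay compound 1 also gives only a limit, > 50000 nM. The measured step that the two limits leave unreadable from compound 1 to compound 2 stays unreadable because of the limit of > 50000 nM in this assay, at which 2 of the 2 values shown sit.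

Compound 3, `N#CC1=C(N)Oc2c(N)cc3nc4ccccc4nc3c2C12C(=O)N(Cc1cnnn1-c1c(F)cccc1F)c1ccccc12`, differs from compound 2 by a single change: 2,6-difluorophenyl in place of 3,5-dimethylphenyl on an aromatic nitrogen. Among the measured compounds shown here, the one measured step touches the same position but yields no size, so it gives no direction for this new change. Compound 3 is therefore expected to stay near the same limit, with an estimated step that the limit leaves unreadable from compound 2 to compound 3. The estimate for compound 3 in this assay is 60000 nM, in a range from 15000 nM to 250000 nM.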

Compound 3, half-maximal inhibitory concentration: > 50000 nM
Compound 3: no number, only a limit; the forecaster's own chance of this, stated with the estimate: 80%; the middle value does not contradict the limit.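

No step can be read among compound 1, compound 2 and compound 3 in this assay, because each gives only a limit, not a number: the limit of > 50000 nM in this assay, at which 3 of the 3 values shown sit. The compounds shown leave open which group on the aromatic nitrogen, if any, would give a measurable value.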